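Branching the alkyl chain on a triarylethylene aromatase inhibitor

A few compounds are considered here, and "the series" means these few. Any claim that something is new, unique, unknown or untested is made for them only; others in the source may bear on it.

In an assay on isolated protein for inhibition of Aromatase (Homo sapiens), read by fluorescence, with a stated time of 30 min (a lower number here means a stronger inhibitor, a higher number a weaker inhibitor), the measured compounds gave the following:
- compound 1, `CC/C(=C(/c1ccc(O)cc1)c1ccc(OCCO)cc1)c1ccccc1`: 30500 nM
- compound 2, `CCC/C(=C(/c1ccc(O)cc1)c1ccc(OCCN)cc1)c1ccccc1`: 261 nM
- compound 3, `CC/C(=C(/c1ccc(N)cc1)c1ccc(OCCN)cc1)c1ccc(O)cc1`: 48.1 nM

Compound 2 stands second highest of the three numbers in this assay. Its nearest neighbour is compound 3, whose number is lower by more than the usual scatter, and the furthest is compound 1, whose number is higher by a wide margin, also beyond the scatter. No pair of these compounds differs in only one place, so the numbers show only where each compound lands, not what any single change does.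

Compound 4, `CC(C)/C(=C(/c1ccc(O)cc1)c1ccc(OCCN)cc1)c1ccccc1`, differs from compound 2 in one place: isopropyl in place of propyl on a double-bonded chain carbon bound to an aromatic carbon and a double-bonded chain carbon. The same atoms are present in both, only joined differently.

Within the data shown here, with no comparable step among the measured compounds, the size of this change is uncertain. The expected step from compound 2 to compound 4 in this assay is a 1.5-fold higher number from compound 2 to compound 4 (0.19 log units; within the scatter), estimated as a small rise in the number, close to the scatter. Compound 4 is therefore expected to give about 400 nM, with a plausible range from 120 nM to 1500 nM.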

Compound 4, half-maximal inhibitory concentration: 328 nM
Compound 4: the middle estimate sits 1.2-fold (0.09 log units) above what was measured; measured number inside the range.
By their numbers in this assay, from the lowest: compound 3; then compounds 2 and 4 (each within the scatter of the next); then compound 1.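

Replacing propyl with isopropyl gives, in this assay, a 1.3-fold higher number from compound 2 to compound 4 (0.10 log units; within the scatter), so this pair cannot be told apart by its numbers. Among these compounds, this is the first comparison here in which only one place differs, and it shows that branching the chain on a double-bonded chain carbon bound to an aromatic carbon and a double-bonded chain carbon, using the same three carbons, produces no change that this measurement can resolve. The earlier compounds could show only where each one landed, whereas this pair tests the arrangement of the chain directly, and no measurement here offers an explanation for the result.

From the compounds shown here alone, whether a longer chain such as butyl, a ring such as cyclopropyl, or a chain carrying an amine would also leave the number within the scatter of compound 2 remains open. A single pair also cannot show whether swapping propyl for isopropyl would read the same way on a different core, such as the core of compound 3.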